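The source may hold more compounds than are shown below. What is called first, only, known or untested is meant among the compounds shown, and "the series" means these compounds.

Working notes on the urea series sharing the core of compound 1 `COc1cc(Cl)cc(-c2nn(-c3cccc(NC(=O)Nc4ccc(Cl)c(C(F)(F)F)c4)c3)cc2-c2ccncc2)c1`. Among the compounds with values here, only two members have numbers so far, both measured in a functional assay on PC-3 cells (Homo sapiens) for inhibition, read by sulforhodamine B assay, with a stated time of 48 h, tested at 0.01 uM (on this read-out lower numbers stand for a stronger effect and higher numbers for a weaker effect at the one concentration tested), at a single low concentration. Compound 1 gives 94%. Compound 2 `COc1cc(Cl)cc(-c2nn(-c3cccc(NC(=O)Nc4cc(C(F)(F)F)cc(C(F)(F)F)c4)c3)cc2-c2ccncc2)c1`, which carries a second trifluoromethyl group on the outer ring in place of the chloro, gives 101%. The two numbers lie within the usual scatter of each other, so nothing separates compound 1 from compound 2 on this read-out; both sit close to no measurable effect at the concentration used.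

The next member, compound 3 `COc1cc(Cl)cc(-c2nn(-c3cccc(NC(=O)Nc4cccc(C(F)(F)F)c4)c3)cc2-c2ccncc2)c1`, differs from compound 1 in one place: hydrogen in place of chloro on an aromatic carbon. With compound 1 and compound 2 both near the top of the scale, no step beyond the scatter is expected in this assay from the loss of the chloro; the step from compound 1 to compound 3 is estimated as a number 3 percentage points higher from compound 1 to compound 3 (within the scatter). Compound 3 is expected to give about 97%, most likely between 85% and 108%.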

Compound 3, a percentage reported as activity, at one concentration (the size of the read-out at that concentration, not a potency): 91%
For compound 3 the middle estimate is 6 percentage points above the measured one; the range from low to high includes it.
By their numbers in this assay, from the lowest: compounds 3, 1 and 2 (each within the scatter of the next).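

In this assay, hydrogen in place of chloro, ortho to a trifluoromethyl group, gives a number 3 percentage points lower from compound 1 to compound 3 (within the scatter), and hydrogen in place of trifluoromethyl gives a number 10 percentage points lower from compound 2 to compound 3 (within the scatter). Neither step leaves the scatter, so a 3-(trifluoromethyl)phenyl group bearing no further substituent on the ring cannot be told apart on this read-out from either of the two more heavily substituted rings, and the chloro at this place does not change the reading at the one concentration tested. No measurement at hand bears on why these numbers coincide.

Going by these compounds, whether an amine, a carboxylic acid or a methoxy group at this place would move the number beyond the scatter stays open. Also open, on these data alone, is whether these compounds would separate at a concentration where the read-out falls well away from no measurable effect.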